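The compounds below may be only part of what the source reports. "The series", "measured", "known", "first", "only" and "open" are said of these compounds alone.

Measured so far in a functional assay on HOS cells (Homo sapiens) for antiproliferative activity, with a stated time of 72 h; a lower number here means a stronger inhibitor, a higher number a weaker inhibitor:
- compound 1 `OC[C@H]1O[C@@H](n2cnc3c(NCc4ccc(F)cc4)ncnc32)[C@H](O)[C@@H]1O`: 13200 nM
- compound 2 `OC[C@H]1O[C@@H](n2cnc3c(NCc4ccc(F)cc4F)ncnc32)[C@H](O)[C@@H]1O`: > 166000 nM (a limit)

Compound 2 gives no number in this assay, only a limit of the assay, > 166000 nM. That limit is the limit of > 166000 nM in this assay, at which 1 of the 2 values shown sits.

The next compound is compound 3 `OC[C@H]1O[C@@H](n2cnc3c(NCc4ccc(F)c(Cl)c4)ncnc32)[C@H](O)[C@@H]1O`, still unmeasured. In it, 3-chloro-4-fluorophenyl stands in place of 2,4-difluorophenyl on a saturated chain carbon bound to a nitrogen on an aromatic ring: 3-chloro-4-fluorophenyl in place of 2,4-difluorophenyl on a saturated chain carbon bound to a nitrogen on an aromatic ring.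

For the measured compounds named here, one measured step bears on this change: an at least 12-fold higher number from compound 1 to compound 2 (1.09 log units; beyond the scatter). This large step is a fluoro in place of hydrogen on an aromatic carbon, and it produced the 2,4-difluorophenyl group that compound 3 no longer carries. A sizeable step to a lower number, meaning a stronger inhibitor, is therefore expected in this assay. The expectation leans on compound 1, which gives 13200 nM. With a single step as the basis, a second limit remains possible.

The expected step is an at least 8.3-fold lower number from compound 2 to compound 3 (0.91 log units; beyond the scatter). For compound 3 the estimated value is 20000 nM, with an expected range of 5000 nM to 100000 nM.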

Compound 3, half-maximal inhibitory concentration: > 166000 nM
Compound 3 was reported as a limit; the forecaster's own chance of this, stated with the estimate: 25%; middle value at least 8.3-fold (0.91 log units) away from the limit.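

In this assay, compound 3 gives > 166000 nM, which is a limit of the assay and not a number, and it is the same limit that compound 2 reached: the limit of > 166000 nM in this assay, at which 2 of the 3 values shown sit.

The step between these two compounds cannot be read, so 3-chloro-4-fluorophenyl and 2,4-difluorophenyl cannot be ordered on this read-out. What is new is the second route away from compound 1: the atom added to the aromatic ring is now a chlorine, and the result is an at least 12-fold higher number from compound 1 to compound 3 (1.09 log units; beyond the scatter), so a large loss is no longer tied to fluoro as the added atom. In both compounds shown that carry an added halogen on the aromatic ring of compound 1, the read-out moves to the limit, and no compound shown goes against this.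

As far as these compounds go, how far compound 2 and compound 3 lie past the limit stays open, as does whether the position of the added halogen matters at all. Also open, from the compounds shown here alone, is whether a methyl or methoxy group in place of that same hydrogen, or an amine there, would keep a measurable value.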